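From methoxy to (oxolan-3-yl)oxy in the 2-nitrophenyl series

The compounds below may be only part of what the source reports. "The series", "measured", "known", "first", "only" and "open" are said of these compounds alone.

In a functional assay on PC-3 cells (Homo sapiens) for cytotoxicity, read by MTT assay, with a stated time of 72 h (a lower number here means a stronger inhibitor, a higher number a weaker inhibitor), compound 1 (`COc1cc2ncnc(Nc3ccc(F)c(Cl)c3)c2cc1NC(=O)/C=C/c1ccccc1[N+](=O)[O-]`) gives 14300 nM, the lower of the two numbers available, and compound 2 (`COc1ccc(/C=C/C(=O)Nc2cc3c(Nc4ccc(F)c(Cl)c4)ncnc3cc2OC)c(OC)c1`) gives 38500 nM. Compound 3 (`O=C(/C=C/c1ccccc1[N+](=O)[O-])Nc1cc2c(Nc3ccc(F)c(Cl)c3)ncnc2cc1O[C@H]1CCOC1`) keeps the 2-nitrophenyl of compound 1 and changes a different place: oxolan-3-yl in place of methyl on an oxygen on an aromatic ring. In words, oxolan-3-yl stands in place of methyl on an oxygen on an aromatic ring. Among the measured compounds shown here, no measured step touches that place. The only one available, a 2.7-fold higher number from compound 1 to compound 2 (0.43 log units; beyond the scatter), is modest and serves as a rough yardstick of size, without giving a direction. In this assay, a step no larger than that one is therefore expected, possibly none beyond the scatter. The estimated move is a 1.2-fold lower number from compound 1 to compound 3 (0.08 log units; within the scatter). For compound 3 the expected value is 12000 nM, with an estimated range of 5000 nM to 30000 nM.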

Compound 3, half-maximal inhibitory concentration: 7760 nM
The estimate for compound 3 lay 1.5-fold (0.19 log units) above the measured number; measured number inside the range.
By their numbers in this assay, from the lowest: compounds 3 and 1 (each within the scatter of the next); then compound 2.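

At the oxygen on an aromatic ring, oxolan-3-yl in place of methyl reads in this assay as a 1.8-fold lower number from compound 1 to compound 3 (0.27 log units; within the scatter) and so stays inside the usual scatter. Among the compounds shown here, the only earlier step, a 2.7-fold higher number from compound 1 to compound 2 (0.43 log units; beyond the scatter), lay at the other end of the molecule, whereas this one shows that the place on the oxygen accepts a group of 5 heavy atoms, with one five-membered non-aromatic ring and one defined stereocentre, without a step beyond the scatter. No measurement is available that bears on the reason for this result.

As far as these compounds go, whether the same change reads alike with the 2,4-dimethoxyphenyl of compound 2, and whether the opposite stereoisomer of oxolan-3-yl matches compound 3, remains open. Also open, from the compounds shown here alone, is how a longer chain ending in an amine would read on the same oxygen.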